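A few compounds are considered here, and "the series" means these few. Any claim that something is new, unique, unknown or untested is made for them only; others in the source may bear on it.

In a functional assay on C8166 cells (Homo sapiens) for cytotoxicity, read by MTT assay (on this read-out lower numbers stand for higher toxicity in this test and higher numbers for lower toxicity in this test), compound 1 `Cc1cc(S(N)(=O)=O)ccc1NC(=O)COc1ccc(Cl)cc1NC(=O)c1ccccc1C` gives 67300 nM and compound 2 `Cc1cccc(C(=O)Nc2cc(Cl)ccc2OCC(=O)Nc2ccc(S(N)(=O)=O)cc2C)c1` gives 52900 nM. Compound 2 holds the lowest of these two numbers, yet the step of a 1.3-fold lower number from compound 1 to compound 2 (0.10 log units; within the scatter) means the two values cannot be told apart. Compound 3 `Cc1cc(S(N)(=O)=O)ccc1NC(=O)COc1ccc(Cl)cc1NC(=O)c1cc(Cl)cc(Cl)c1` differs from compound 2 by 3,5-dichlorophenyl in place of 3-methylphenyl on a carbonyl carbon. For the measured compounds named here, no measured step swaps a methyl for two chlorines; the only measured step, a 1.3-fold lower number from compound 1 to compound 2 (0.10 log units; within the scatter), concerns a different change and stayed within the scatter, so nothing here points to a large shift. The expected step is a 1.2-fold lower number from compound 2 to compound 3 (0.07 log units; within the scatter). For compound 3 in this assay the estimate is 45000 nM, ranging from 15000 nM to 140000 nM.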

Compound 3, half-maximal cytotoxic concentration: 72400 nM
Estimate against measurement, compound 3: 1.6-fold (0.21 log units) below; low and high end bracket the measured number.
By their numbers in this assay, from the lowest: compounds 2, 1 and 3 (each within the scatter of the next).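

In this assay the 3,5-dichlorophenyl group on this carbonyl carbon gives a 1.4-fold higher number from compound 2 to compound 3 (0.14 log units; within the scatter) and a 1.1-fold higher number from compound 1 to compound 3 (0.03 log units; within the scatter) and so stays within the scatter. Until now only a methyl had changed place on this ring; now two chlorines stand in place of the methyl, and the read-out still cannot tell the compounds apart. Nothing available here offers an explanation for this result. On these data alone, what remains open is whether a ring carrying an amine or a carboxylic acid, or a longer chain in place of the ring, on this carbonyl carbon would move the number beyond the scatter.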